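Defined versus undrawn configuration at the thiol-bearing carbon

The source may hold more compounds than are shown below. What is called first, only, known or untested is meant among the compounds shown, and "the series" means these compounds.

Compound 1 `CCSC[C@@H](NC(=O)[C@@H](CS)Cc1ccccc1)C(=O)O` is the reference point of this small set of thiol amides. In an assay on isolated protein for inhibition of Neprilysin (Oryctolagus cuniculus) (on this read-out higher numbers stand for weaker inhibition and lower numbers for stronger inhibition), compound 1 gives 2.4 nM. Its companions are compound 2 `CC(C)(C)SC[C@@H](NC(=O)[C@@H](CS)Cc1ccccc1)C(=O)O`, which in this assay gives 49 nM, and compound 3 `CSC[C@@H](NC(=O)[C@@H](CS)Cc1ccccc1)C(=O)O`, which in this assay gives 1.5 nM. Compound 1 thus holds the second highest of the three numbers; its nearest neighbour is compound 3, with a 1.6-fold lower number from compound 1 to compound 3 (0.20 log units; within the scatter), and its furthest is compound 2, with a 20-fold higher number from compound 1 to compound 2 (1.31 log units; beyond the scatter). The remaining step, a 33-fold lower number from compound 2 to compound 3 (1.51 log units; beyond the scatter), is also large.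

Compound 4 `CCSC[C@@H](NC(=O)C(CS)Cc1ccccc1)C(=O)O` is the next compound to be measured. It differs from compound 1 as follows: the two compounds have the same atoms and bonds; at least one stereo element is drawn with a configuration in one of them and without one in the other: 1 of 2 stereo elements differ; a stereocentre at a saturated chain carbon is drawn S in compound 1 and without a configuration in compound 4. Nothing else changes; the sulfur substituent is ethyl in both.

For the measured compounds named here, none of the measured steps concerns a stereocentre; all three steps, a 20-fold higher number from compound 1 to compound 2 (1.31 log units; beyond the scatter), a 1.6-fold lower number from compound 1 to compound 3 (0.20 log units; within the scatter) and a 33-fold lower number from compound 2 to compound 3 (1.51 log units; beyond the scatter), vary only the substituent on sulfur. They therefore give no direct guide to the step into compound 4. Where the drawn configuration is lost, the material may contain both configurations at that carbon, and the measured number would then be expected to move towards a somewhat higher value, likely within or just beyond the scatter. The step from compound 1 to compound 4 is estimated as a 1.9-fold higher number from compound 1 to compound 4 (0.27 log units; within the scatter). Compound 4 is therefore expected to give about 4.5 nM, within a range of 1.5 nM to 14 nM.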

Compound 4, half-maximal inhibitory concentration: 6.5 nM
Estimate against measurement, compound 4: 1.4-fold (0.16 log units) below; measured number inside the range.
By their numbers in this assay, from the lowest: compounds 3 and 1 (each within the scatter of the next); then compound 4; then compound 2.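

The change at this stereocentre leaves the sulfur substituent untouched, and a 2.7-fold higher number from compound 1 to compound 4 (0.43 log units; beyond the scatter) shows that the drawn configuration at this saturated chain carbon matters in its own right, separately from anything the sulfur substituent does. The effect is modest, however, and much smaller than the change seen with tert-butyl on sulfur, a 20-fold higher number from compound 1 to compound 2 (1.31 log units; beyond the scatter). With atoms and bonds identical in the pair, only one structural difference is available to account for the higher number for compound 4: the fact that one of compounds 1 and 4 is drawn with a defined configuration and the other without, at the place where they differ

On these data alone, the drawing of compound 4 does not fix how much of each configuration the material holds, so the number for the pure opposite configuration at this carbon remains open, and it could lie well above what compound 4 shows. Also open, as far as these compounds go, is whether the same dependence on configuration holds with a longer chain such as n-butyl on sulfur, or with a carboxylic acid in place of the thiol.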